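From Nitro to Methoxycarbonyl at the Limit of the Assay

The source may report more compounds than this note shows. Statements on the series, on what has been measured and on what is new or still open speak of the compounds shown alone.

Compound 1, `Cc1cc(NC(=O)Nc2cccc([N+](=O)[O-])c2)c2ccccc2n1`, is the starting point for this step. In an ADME assay on Raji cells (Homo sapiens) for cytotoxicity, with a stated time of 72 h (on this read-out lower numbers stand for an effect already at smaller amounts and higher numbers for an effect only at larger amounts of compound), compound 1 gives > 25000 nM, which is a limit of the assay and not a number. Compound 2, `Cc1cc(NC(=O)Nc2ccc3[nH]cnc3c2)c2ccccc2n1`, gives > 25000 nM, and this too is a limit. The two compounds therefore share one position on the scale: the limit of > 25000 nM in this assay, at which 2 of the 2 values shown sit. Going by the values given here, no number is available for either compound, and no measured pair differs in only one place.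

Compound 3, `COC(=O)c1cccc(NC(=O)Nc2cc(C)nc3ccccc23)c1`, keeps the shared core of compound 1 and carries methoxycarbonyl in place of nitro on an aromatic carbon, meta to a large group: methoxycarbonyl in place of nitro on an aromatic carbon.

Among the compounds with values here, no measured step is available to show what such a swap does. Within the data shown here, with the limit of compound 1 at > 25000 nM as the only guide, no step beyond the usual scatter is expected in this assay, in either direction. The estimated change is a number no higher from compound 1 to compound 3 (the limit leaves the size open). For compound 3 the expected value is 25000 nM, with an estimated range from 12000 nM to 50000 nM.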

Compound 3, half-maximal effective concentration: 26000 nM
Compound 3: middle estimate off by 1.0-fold (0.02 log units), on the low side; the measured number falls inside the stated range.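

Going by these compounds alone, compound 1 has only a limit of the assay and not a number, so no step from compound 1 to compound 3 can be read in this assay: the limit of > 25000 nM in this assay, at which 2 of the 3 values shown sit. The compounds shown leave open how far compound 3 lies from compound 1, and so what methoxycarbonyl in place of nitro does on this read-out.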